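The source may hold more compounds than are shown below. What is called first, only, known or untested is meant among the compounds shown, and "the series" means these compounds.

The study compares four compounds in a functional assay on A549 cells (Homo sapiens) for antiproliferative activity, read by MTT assay, with a stated time of 72 h; a lower number here means a stronger inhibitor, a higher number a weaker inhibitor. Compound 1 `COc1cc2ncnc(Nc3cccc(Cl)c3)c2cc1OCCCCC(=O)Nc1ccc(S(N)(=O)=O)cc1` and compound 2 `COc1cc2ncnc(Nc3cccc(Cl)c3F)c2cc1OCCCCC(=O)Nc1ccc(S(N)(=O)=O)cc1` share one core and differ in a single place. In this assay compound 1 gives 11200 nM. In this assay compound 2 gives 10500 nM. The change from compound 2 to compound 1 is hydrogen in place of fluoro on an aromatic carbon, and it made a step of a 1.1-fold higher number from compound 2 to compound 1 (0.03 log units; within the scatter).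

Compound 3 `NS(=O)(=O)c1ccc(NC(=S)Nc2ccc3ncnc(Nc4ccc(F)c(Br)c4)c3c2)cc1` rests on another core; the difference between the two cores is not broken down here. In this assay compound 3 gives only a limit of the assay, > 40000 nM, which is the limit of > 40000 nM in this assay, at which 1 of the 3 values shown sits.

Compound 4 `NS(=O)(=O)c1ccc(NC(=S)Nc2ccc3ncnc(Nc4cccc(Br)c4)c3c2)cc1` has not yet been measured. It differs from compound 3 by hydrogen in place of fluoro on an aromatic carbon. For the measured compounds named here, this is the same kind of change as the one from compound 2 to compound 1, though not the same: in compound 2 the fluoro sits ortho to a chloro group and ortho to a large group, whereas in compound 3 it sits ortho to a bromo group and para to a large group.

Going by the values given here, the one measured instance of this kind of change, a 1.1-fold higher number from compound 2 to compound 1 (0.03 log units; within the scatter), lay within the scatter. The estimated step is a number no higher from compound 3 to compound 4 (the limit leaves the size open), resting on that measured step. Compound 4 is therefore expected to give about 40000 nM in this assay, with an expected range from 18000 nM to 90000 nM, and it may well again yield only a limit.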

Compound 4, half-maximal inhibitory concentration: 25000 nM
The estimate for compound 4 lay 1.6-fold (0.20 log units) above the measured number; the measured number falls inside the stated range.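

In this assay, hydrogen in place of fluoro on the aromatic carbon, turning the 3-bromo-4-fluorophenyl group into the 3-bromophenyl group, gave an at least 1.6-fold lower number from compound 3 to compound 4 (0.20 log units; that floor lies within the scatter). The change has now been read on two cores, but the data do not show that it carries from one core to the other with the same size, nor that its size differs between them: the same change on two cores in this assay, a 1.1-fold higher number (0.03 log units; within the scatter) from compound 2 to compound 1 and an at least 1.6-fold lower number (0.20 log units; that floor lies within the scatter) from compound 3 to compound 4; the limit leaves it open whether they differ The comparison on the second core rests on a single value that is not a number, the one for compound 3: the limit of > 40000 nM in this assay, at which 1 of the 4 values shown sits.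

The compounds shown leave open how the core of compound 4 responds when a chloro or a methyl group stands in place of the bromo group, which would test the change on that core with other neighbours. They also leave open whether a urea in place of the thiourea of compound 4, or a shorter chain or an amine in the linking part of compound 1, would alter the numbers in this assay.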